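Chain extension between the triazole and the anilide

The source may report more compounds than this note shows. Statements on the series, on what has been measured and on what is new or still open speak of the compounds shown alone.

Compound 2 `O=C(CCc1cn(Cc2ccc3oc(-c4ccc(Cl)cc4)cc(=O)c3c2)nn1)Nc1ccccc1` is measured in an assay on isolated protein for inhibition of Amine oxidase [flavin-containing] B (Homo sapiens), read by fluorescence and spectrophotometry (a lower number here means a stronger inhibitor, a higher number a weaker inhibitor), where compound 2 gives 32900 nM. Its nearest neighbour is compound 1 `Cc1ccc(NC(=O)CCc2cn(Cc3ccc4oc(-c5ccc(Cl)cc5)cc(=O)c4c3)nn2)cc1`, which in this assay gives 32900 nM; the step of no change at the digits printed from compound 1 to compound 2 (within the scatter) shows that loss of the methyl leaves the value level within the scatter. Compound 3 `O=C(CCCCc1cn(Cc2ccc3oc(-c4ccc(Cl)cc4)cc(=O)c3c2)nn1)Nc1ccccc1` carries a longer linker: 2-(phenylcarbamoyl)ethyl in place of phenylcarbamoyl on a saturated chain carbon, two bonds along the chain from an aromatic carbon. For the measured compounds named here, no measured step touches the length of this chain, since the one step in hand concerns only the aryl methyl, so nothing here speaks for or against a shift in this assay. With only that to go on, the step from compound 2 to compound 3 is expected to be small, a 1.1-fold lower number from compound 2 to compound 3 (0.04 log units; within the scatter), in no particular direction. In this assay compound 3 is therefore estimated at 30000 nM, with a range from 8000 nM to 110000 nM.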

Compound 3, half-maximal inhibitory concentration: 32900 nM
The estimate for compound 3 lay 1.1-fold (0.04 log units) below the measured number, within the range that was stated.
By their numbers in this assay, from the lowest: compounds 1, 2 and 3 (each within the scatter of the next).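

The position on the saturated chain carbon now has its first reading: in this assay, extending the linker by replacing phenylcarbamoyl with 2-(phenylcarbamoyl)ethyl gives no change at the digits printed from compound 2 to compound 3 (within the scatter), so this added length does not separate the two compounds. Replacing (4-methylphenyl)carbamoyl with the same longer group gives no change at the digits printed from compound 1 to compound 3 (within the scatter), which places all three compounds at one level despite changes at two different sites. Nothing measured here accounts for this flat result.

The compounds shown leave open whether a shorter chain or a much longer one would move the number away from this level. They also leave open whether a carboxylic acid or an amine in place of the anilide would do so.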